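Swapping the aryl group on the hydrazone arm

This account rests on a few compounds, and the source may have more. Where it says the series, first, only, none or still open, it means among the compounds named here.

Measured compounds:
- Compound 1, `CCCSc1nc(N/N=C/c2ccc(N(C)C)cc2)c2nnn(Cc3ccccc3)c2n1`: in a functional assay on MGC-803 cells (Homo sapiens) for antiproliferative activity, read by MTT assay, with a stated time of 72 h (on this read-out lower numbers stand for stronger inhibition and higher numbers for weaker inhibition), compound 1 gives 13100 nM.
- Compound 2, `CCCSc1nc(N/N=C/c2ccccc2F)c2nnn(Cc3ccccc3)c2n1`: in this assay compound 2 gives > 64000 nM, which is a limit of the assay, not a number.

Both compounds share the same core and differ only in the aromatic ring attached to the carbon that carries a double bond to nitrogen. Compound 2 therefore stands at the weak end of what has been measured: its result is only a boundary (the limit of > 64000 nM in this assay, at which 1 of the 2 values shown sits), so the true value could lie anywhere beyond it. Going by the values given here, the one step measured so far, an at least 4.8-fold higher number from compound 1 to compound 2 (0.68 log units; beyond the scatter), shows that changing this aryl group can shift the read-out by a sizeable margin.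

Compound 3, `CCCSc1nc(N/N=C/c2ccc([N+](=O)[O-])cc2)c2nnn(Cc3ccccc3)c2n1`, has not yet been tested. Its change from compound 2 is 4-nitrophenyl in place of 2-fluorophenyl on a carbon with a double bond to nitrogen. Among the compounds with values here, since compound 2 is known only as a limit, no step can be sized with confidence, and the nitro-bearing ring has no measured counterpart here.

The expectation for compound 3 is a value of 30000 nM, between 8000 nM and 64000 nM, with a fair chance that it again sits at a limit. This estimate corresponds to a step of an at least 2.1-fold lower number from compound 2 to compound 3 (0.32 log units; beyond the scatter).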

Compound 3, half-maximal inhibitory concentration: 10100 nM
Estimate against measurement, compound 3: 3.0-fold (0.47 log units) above, within the range that was stated.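

Replacing 2-fluorophenyl with 4-nitrophenyl on a carbon with a double bond to nitrogen restores a measurable result in this assay, with an at least 6.3-fold lower number from compound 2 to compound 3 (0.80 log units; beyond the scatter). That step has only a bound on its size, and its true size could be larger, since the result for compound 2 is a limit of the assay and not a number: the limit of > 64000 nM in this assay, at which 1 of the 3 values shown sits. The other new comparison, nitro in place of dimethylamino on an aromatic carbon, gives a 1.3-fold lower number from compound 1 to compound 3 (0.11 log units; within the scatter), so the read-out does not separate these two compounds, even though the two groups are different in kind.

On these data alone, whether the weak result of compound 2 belongs to the fluorine itself or to where it sits on the ring remains open, and a 4-fluorophenyl group or a plain phenyl group in the same place would be the comparison that could separate the two. Also open, as far as these compounds go, is whether any group on this ring, such as a carboxylic acid, a methoxy group or a primary amine, could move the number well past what compound 1 and compound 3 show.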